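The compounds below may be only part of what the source reports. "The series", "measured", "known", "first", "only" and "open" are said of these compounds alone.

Compound 3 `CC(C)CSc1nc(N)nc2c1ncn2/C=C1/CC1(CO)CO` was examined in an ADME assay on BCBL1 cells (Homo sapiens) for cytotoxicity, with a stated time of 7 days; on this read-out higher numbers stand for lower toxicity in this test and lower numbers for higher toxicity in this test. In this assay compound 3 gives > 20000 nM, which is a limit of the assay and not a number. Compound 1 `CCCCSc1nc(N)nc2c1ncn2/C=C1/CC1(CO)CO` was run in this assay as well, and compound 1 gives > 20000 nM, again a limit rather than a number. Compound 2 `Nc1nc(NC2CCCCC2)c2ncn(/C=C3/CC3(CO)CO)c2n1` was also run, and in this assay compound 2 gives > 20000 nM, once more a limit. All three values sit at the limit of > 20000 nM in this assay, at which 3 of the 3 values shown sit. The step that the two limits leave unreadable from compound 1 to compound 3 therefore cannot be read, and the same holds for a step that the two limits leave unreadable from compound 1 to compound 2 and a step that the two limits leave unreadable from compound 2 to compound 3. Compound 4 `CCCOc1nc(N)nc2c1ncn2/C=C1/CC1(CO)CO` has not yet been measured in this assay. It differs from compound 3 by propoxy in place of isobutylsulfanyl on an aromatic carbon. Going by the values given here, none of the measured steps gives a readable size for a change of this kind, as every value shown is a limit. The expected step of a number no higher from compound 3 to compound 4 (the limit leaves the size open) is accordingly none beyond the scatter. Compound 4 is estimated to give 20000 nM in this assay, within a range from 10000 nM to 40000 nM, and is most likely to be reported again only as a limit.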

Compound 4, half-maximal cytotoxic concentration: > 20000 nM
Compound 4: no number, only a limit; the forecaster's own chance of this, stated with the estimate: 85%; the middle value lies on the limit itself.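

In this assay compound 4 gives > 20000 nM, a limit and not a number, so no step between compound 4 and compounds 1, 2 or 3 can be read: the limit of > 20000 nM in this assay, at which 4 of the 4 values shown sit.

The compounds shown leave open whether these four differ at all in this assay.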